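This account rests on a few compounds, and the source may have more. Where it says the series, first, only, none or still open, it means among the compounds named here.

Compound 1 `COc1ccc(C(=O)Nc2c(F)cccc2F)cc1OC1CCCC1` is the starting point. In an assay on isolated protein for inhibition of phosphodiesterase 4A (Sus scrofa) (a lower number here means a stronger inhibitor, a higher number a weaker inhibitor), compound 1 gives 70 nM, the lowest of the three numbers: compound 2 `COc1ccc(C(=O)Nc2c(F)cccc2F)cc1OC1CCCCC1` gives 400 nM, and compound 3 `O=C(Nc1c(F)cccc1F)c1cccc(OC2CCCC2)c1` gives 15000 nM. Both measured steps alter the ether-bearing end of the shared core: a 5.7-fold higher number from compound 1 to compound 2 (0.76 log units; beyond the scatter) and a 210-fold higher number from compound 1 to compound 3 (2.33 log units; beyond the scatter). Compound 4 `COc1ccc(C(=O)Nc2cnccn2)cc1OC1CCCC1` is built instead by changing the amide side: pyrazin-2-yl in place of 2,6-difluorophenyl on an amide-type nitrogen. Neither measured step touches this part of the molecule, so they offer no direct guide to the size or direction of the change. Without such a guide, a moderate weakening is expected for compound 4, a 4.3-fold higher number from compound 1 to compound 4 (0.63 log units; beyond the scatter), with wide uncertainty. Compound 4 is therefore estimated at 300 nM in this assay, within a range from 50 nM to 2000 nM.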

Compound 4, half-maximal inhibitory concentration: 250 nM
Compound 4: middle estimate off by 1.2-fold (0.08 log units), on the high side; the range from low to high includes it.
By their numbers in this assay, from the lowest: compound 1; then compounds 4 and 2 (each within the scatter of the next); then compound 3.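

Replacing 2,6-difluorophenyl with pyrazin-2-yl on the amide-type nitrogen has a real effect in this assay (a 3.6-fold higher number from compound 1 to compound 4 (0.55 log units; beyond the scatter)), so the amide side also affects this number. This step is much smaller than the one from removing the methoxy (a 210-fold higher number from compound 1 to compound 3 (2.33 log units; beyond the scatter)), even though an entire aromatic ring is exchanged. No measurement here explains the step.

On these data alone, it remains open whether the lost fluorines or the added ring nitrogens matter more. A plain phenyl, a pyridyl ring or a butyl chain on this nitrogen could help separate these contributions.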